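Swapping Chloro for Dimethylamino on the Aryl Ring

The source may hold more compounds than are shown below. What is called first, only, known or untested is meant among the compounds shown, and "the series" means these compounds.

Of the compounds shown here, two have so far been measured in a functional assay, with a stated time of 10 min; on this read-out lower numbers stand for stronger inhibition and higher numbers for weaker inhibition. Compound 1 `Cn1c(NN)nc(-c2ccc(Cl)cc2)c(C#N)c1=O` gives 41 ug/mL in this assay. Compound 2 `CCOC(=O)c1cnn(-c2nc(-c3ccc(OC)cc3)c(C#N)c(=O)n2C)c1N` gives 74 ug/mL in this assay. Compound 1 carries the lowest of the two numbers, but its gap to compound 2 falls within the scatter of repeated measurements, so the two cannot be told apart on these data.

Compound 3 `CN(C)c1ccc(-c2nc(NN)n(C)c(=O)c2C#N)cc1` has not yet been measured. It differs from compound 1 in a single place: dimethylamino in place of chloro on an aromatic carbon. For the measured compounds named here, no pair of measured compounds shows what this kind of change does in this assay, so there is no measured step to lean on. The step of a 1.1-fold higher number from compound 1 to compound 3 (0.04 log units; within the scatter) is expected to stay within the scatter, with no clear direction. The estimate for compound 3 is 45 ug/mL, ranging from 15 ug/mL to 130 ug/mL.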

Compound 3, half-maximal inhibitory concentration: 66 ug/mL
Estimate against measurement, compound 3: 1.5-fold (0.17 log units) below; the range from low to high includes it.
By their numbers in this assay, from the lowest: compounds 1, 3 and 2 (each within the scatter of the next).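

In this assay, for the compounds shown here, this is the first comparison in which only one place on the molecule changes, and the swap of chloro for dimethylamino gives a 1.6-fold higher number from compound 1 to compound 3 (0.21 log units; within the scatter). On an aromatic carbon para to a large group, a single chlorine atom can therefore give way to dimethylamino, with its three heavy atoms and one hydrogen-bond acceptor, without a difference these measurements can resolve. No measurement of any property of these groups is available to help interpret this result.

From the compounds shown here alone, whether another group at this position, such as fluoro, a carboxylic acid or a longer alkyl chain, would move the number beyond the scatter remains open. A single step also cannot show whether this swap would behave the same way on a different core.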